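Ecdysone agonist series: from compound 3 to compound 4

The compounds below may be only part of what the source reports. "The series", "measured", "known", "first", "only" and "open" are said of these compounds alone.

Compound 1 `CC(C)(C)N(NC(=O)c1ccccc1)C(=O)c1ccccc1F` gives 309 nM in an assay on cells for agonist activity at ecdysone receptor (Bombyx mori), read by a luciferase reporter, with a stated time of 24 h (on this read-out higher numbers stand for an effect only at larger amounts of compound and lower numbers for an effect already at smaller amounts), compound 2 `CC(C)(C)N(NC(=O)c1ccccc1)C(=O)c1ccccc1I` gives 105 nM, and compound 3 `CC(C)(C)N(NC(=O)c1cccc(Br)c1)C(=O)c1ccccc1Cl` gives 191 nM. Compound 3 thus stands second highest of the three numbers; its gaps to compound 1 and to compound 2 are both within the scatter. Among the compounds with values here, the only single-site step measured so far, a 2.9-fold lower number from compound 1 to compound 2 (0.47 log units; beyond the scatter), concerns the other aromatic ring, the one that carries the halogen, not the ring changed here. Compound 4 `Cc1cccc(C(=O)NN(C(=O)c2ccccc2Cl)C(C)(C)C)c1C` differs from compound 3 by 2,3-dimethylphenyl in place of 3-bromophenyl on a carbonyl carbon. Within the data shown here, no measured step bears on this change, so no step beyond the scatter is expected in this assay. The expected step of a 1.3-fold lower number from compound 3 to compound 4 (0.10 log units; within the scatter) accordingly sits within the scatter. Compound 4 is estimated at 150 nM, with a range of 50 nM to 450 nM.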

Compound 4, half-maximal effective concentration: 20 nM
Compound 4: the middle estimate sits 7.5-fold (0.88 log units) above what was measured, outside the stated range (below it).
By their numbers in this assay, from the lowest: compound 4; then compounds 2, 3 and 1 (each within the scatter of the next, the first and the last beyond it).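

Working from the carbonyl carbon bonded to the amide-type nitrogen, this ring is no silent spot: 2,3-dimethylphenyl in place of 3-bromophenyl gives a 9.6-fold lower number from compound 3 to compound 4 (0.98 log units; beyond the scatter) in this assay and so marks the first step read at this place. This step is larger than the only earlier one, a 2.9-fold lower number from compound 1 to compound 2 (0.47 log units; beyond the scatter), which concerned the other ring. No available evidence explains the step. Open, on these data alone, is whether it follows from losing the bromine or from either methyl group alone. Also open, as far as these compounds go, is how a methoxy group or an amine would fare on this ring.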